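Methoxy addition on a trimethoxy-arene lactone: expected step

The source may hold more compounds than are shown below. What is called first, only, known or untested is meant among the compounds shown, and "the series" means these compounds.

Compound 1 `COc1ccc(/C=C/c2cc(=O)cco2)cc1` is the reference on the first core. In a functional assay on HT-29 cells (Homo sapiens) for inhibition, read by sulforhodamine B assay, with a stated time of 48 h (a lower number here means a stronger inhibitor of growth, a higher number a weaker inhibitor of growth), compound 1 gives 379 uM. Compound 2 `COc1ccc(/C=C/c2cc(=O)cco2)cc1OC` carries one added group, the change being (methoxy in place of hydrogen on an aromatic carbon); in this assay compound 2 gives 807 uM, a step of a 2.1-fold higher number from compound 1 to compound 2 (0.33 log units; beyond the scatter).

Compound 3 `COc1cc(/C=C/C2CC=CC(=O)O2)cc(OC)c1` sits on a second core; the difference between the two cores is not broken down here. In this assay compound 3 gives 8.2 uM, the lowest number among the three measured compounds, with both compound 1 and compound 2 standing well beyond the scatter above it.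

Compound 4 `COc1cc(/C=C/C2CC=CC(=O)O2)cc(OC)c1OC` is not yet measured. It differs from compound 3 by methoxy in place of hydrogen on an aromatic carbon. Among the measured compounds shown here, this is the same kind of change as the one from compound 1 to compound 2, but not the same: in compound 2 the entering group sits ortho to a methoxy group (2 heavy atoms) and meta to a group of 9 heavy atoms, whereas in compound 4 it sits ortho to two methoxy groups (2 heavy atoms each) and para to a group of 9 heavy atoms. For the measured compounds named here, only one measured pair carries this kind of change, so the expectation rests on a single step.

Going by the values given here, for compound 4 in this assay the step is estimated at a 1.8-fold higher number from compound 3 to compound 4 (0.26 log units; within the scatter), a weakening of similar size to that from compound 1 to compound 2, because a 2.1-fold higher number from compound 1 to compound 2 (0.33 log units; beyond the scatter) is the only precedent available. Compound 4 is expected to give about 15 uM, likely between 5 uM and 45 uM.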

Compound 4, concentration for growth inhibition (reported as GI): 18.8 uM
For compound 4 the middle estimate is 1.3-fold (0.10 log units) below the measured one; low and high end bracket the measured number.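

In this assay, among the compounds shown here, methoxy in place of hydrogen on an aromatic carbon gives a 2.3-fold higher number from compound 3 to compound 4 (0.36 log units; beyond the scatter), and this step matches the earlier one on the core of compound 1 in direction and size: the same change on two cores in this assay, a 2.1-fold higher number (0.33 log units; beyond the scatter) from compound 1 to compound 2 and a 2.3-fold higher number (0.36 log units; beyond the scatter) from compound 3 to compound 4, 1.1-fold (0.03 log units) apart, within the scatter of two such steps The change therefore carries across these two cores as a modest rise in the number, even though the entering methoxy in compound 4 sits ortho to two methoxy groups and para to a group of 9 heavy atoms, a different setting from the one in compound 2. For the compounds shown here, this rests on only two pairs in a single assay, however, and core and placement differ together between them, so the agreement neither separates the contribution of each nor establishes a general rule for other cores or other positions.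

The compounds shown leave open whether the step is particular to methoxy, since a hydroxyl group, an amine or a longer chain such as ethoxy on the same aromatic carbon could behave differently. The single change that separates the two cores also remains unresolved, as no pair shown differs only in the core.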